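Exchanging One Halogenated Phenyl for Another at the Ceiling

This account rests on a few compounds, and the source may have more. Where it says the series, first, only, none or still open, it means among the compounds named here.

Measured compounds:
compound 1 `COc1cc(O)c(C(=O)/C=C/c2ccc(OC)c(OCc3cn(-c4ccc(F)c(Cl)c4)nn3)c2)c(OC)c1` — > 100 ug/mL
compound 2 `COc1cc(OC)c2c(=O)cc(-c3ccc(OCc4cn(-c5ccc(F)cc5Cl)nn4)c(OC)c3)oc2c1` — > 100 ug/mL

In an ADME assay on Huh-7 cells (Homo sapiens) for cytotoxicity, read by MTT assay, with a stated time of 72 h (on this read-out higher numbers stand for lower toxicity in this test and lower numbers for higher toxicity in this test), compound 1 gives only a limit, > 100 ug/mL, and not a number. Compound 2 likewise reaches only a limit in this assay, > 100 ug/mL. Both values sit at the limit of > 100 ug/mL in this assay, at which 2 of the 2 values shown sit, so compound 1 stands at the ceiling of the test and cannot be told apart from compound 2 on the numbers shown. Going by the values given here, no step between two measured compounds exists here, since the two differ in more than one place.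

Compound 3 `COc1cc(O)c(C(=O)/C=C/c2ccc(OC)c(OCc3cn(-c4ccc(F)cc4F)nn3)c2)c(OC)c1` is not yet measured. It differs from compound 1 by 2,4-difluorophenyl in place of 3-chloro-4-fluorophenyl on an aromatic nitrogen. Because both measured values rest at the limit of > 100 ug/mL in this assay, at which 2 of the 2 values shown sit, and the change exchanges one halogenated ring for another, no movement beyond the usual scatter is expected; the estimated step is a step that the limit leaves unreadable from compound 1 to compound 3. Compound 3 is therefore expected to give about 120 ug/mL, between 60 ug/mL and 250 ug/mL, most probably reported again only as a limit in this assay.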

Compound 3, half-maximal cytotoxic concentration: > 100 ug/mL
Compound 3: only a limit was reported; the forecaster's own chance of this, stated with the estimate: 80%; the middle value lies beyond the limit too.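

No step can be read between compound 1 and compound 3, since both values are limits and not numbers: the limit of > 100 ug/mL in this assay, at which 3 of the 3 values shown sit. The compounds shown leave open what number any of them would give in this assay, and whether 2,4-difluorophenyl in place of 3-chloro-4-fluorophenyl changes it.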